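Cytotoxicity notes: carbamate series, aryl swap

This account rests on a few compounds, and the source may have more. Where it says the series, first, only, none or still open, it means among the compounds named here.

Measured so far:
- Compound 1 `CN(C)CCCCN(C(=O)O)c1ccc(N2N=C(c3ccc(F)cc3)C3C=CC=CC3C2=O)cc1` — 21800 nM
- Compound 2 `CN(C)CCCCOC(=O)Nc1ccc(Cn2nc(-c3ccncc3)c3ccccc3c2=O)cc1` — 62700 nM

In an ADME assay on Huh-7 cells (Homo sapiens) for cytotoxicity, read by MTT assay, with a stated time of 48 h (on this read-out lower numbers stand for higher toxicity in this test and higher numbers for lower toxicity in this test), compound 2 gives 62700 nM, the higher of the two numbers. Going by the values given here, compound 1 gives 21800 nM in this assay, a lower number, and the gap between compound 1 and compound 2 lies beyond the scatter; the two compounds differ in several places at once, so no single step can be drawn from them.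

Compound 3 `CN(C)CCCCOC(=O)Nc1ccc(Cn2nc(-c3ccccc3F)c3ccccc3c2=O)cc1` is the unmeasured member. It differs from compound 2 in one place: 2-fluorophenyl in place of pyridin-4-yl on an aromatic carbon. Nothing measured here shows how this assay answers such an exchange on the shared core, so the expected step from compound 2 to compound 3 is small, a 1.3-fold lower number from compound 2 to compound 3 (0.10 log units; within the scatter), and not beyond the scatter in either direction. Compound 3 is therefore estimated at 50000 nM in this assay, with a range from 20000 nM to 120000 nM.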

Compound 3, half-maximal cytotoxic concentration: 52500 nM
The estimate for compound 3 lay 1.1-fold (0.02 log units) below the measured number; low and high end bracket the measured number.
By their numbers in this assay, from the lowest: compound 1; then compounds 3 and 2 (each within the scatter of the next).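

In this assay, 2-fluorophenyl in place of pyridin-4-yl on this aromatic carbon next to the ring nitrogen gives a 1.2-fold lower number from compound 2 to compound 3 (0.08 log units; within the scatter), the first single-place step readable in the series. At this position, therefore, a carbon-only aromatic ring carrying fluorine can replace a ring with one hetero atom and one hydrogen-bond acceptor while the read-out stays within the scatter, though this rests on a single pair. No accompanying measurement bears on this result.

On these data alone, whether a carboxylic acid on the aryl ring, a morpholine ring or a plain methyl at this position would give a step beyond the scatter remains open. Compound 1, at 21800 nM, differs from the other two in several places, so it says nothing about this position.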